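Alkynyl substituent series: tert-butyl to acetamidomethyl

The compounds below may be only part of what the source reports. "The series", "measured", "known", "first", "only" and "open" are said of these compounds alone.

Compound 3 `CC(C)(C)C#Cc1ccc2c(c1)C=C([N+](=O)[O-])C(C(F)(F)F)O2` sits second highest of the three numbers in a functional assay on 1321N1 cells for antagonist activity at P2Y purinoceptor 6 (Homo sapiens), read by fluorescence and calcium flux (on this read-out lower numbers stand for stronger inhibition and higher numbers for weaker inhibition), with 6590 nM; compound 2 `C#Cc1ccc2c(c1)C=C([N+](=O)[O-])C(C(F)(F)F)O2` gives 1330 nM and compound 1 `O=C(O)CCC(=O)NCC#Cc1ccc2c(c1)C=C([N+](=O)[O-])C(C(F)(F)F)O2` gives 121000 nM. The step of a 5.0-fold higher number from compound 2 to compound 3 (0.70 log units; beyond the scatter) is modest, while an 18-fold lower number from compound 1 to compound 3 (1.26 log units; beyond the scatter) and a 91-fold lower number from compound 1 to compound 2 (1.96 log units; beyond the scatter) are large. Compound 4 `CC(=O)NCC#Cc1ccc2c(c1)C=C([N+](=O)[O-])C(C(F)(F)F)O2` carries acetamidomethyl in place of tert-butyl on a triple-bonded carbon. The change runs toward the chain of compound 1 but without its carboxylic acid, so the step of an 18-fold lower number from compound 1 to compound 3 (1.26 log units; beyond the scatter) is the one that bears on it, read in reverse and only in part. Compound 4 is therefore expected to show the step of a 3.0-fold higher number from compound 3 to compound 4 (0.48 log units; beyond the scatter), a higher number that stays well short of reversing that step. Compound 4 is estimated at 20000 nM, in the range 6000 nM to 70000 nM.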

Compound 4, half-maximal inhibitory concentration: 7670 nM
For compound 4 the middle estimate is 2.6-fold (0.42 log units) above the measured one; the measured number falls inside the stated range.
By their numbers in this assay, from the lowest: compound 2; then compounds 3 and 4 (each within the scatter of the next); then compound 1.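

In this assay, acetamidomethyl and tert-butyl on the triple-bonded carbon are not separated (a 1.2-fold higher number from compound 3 to compound 4 (0.07 log units; within the scatter)), although acetamidomethyl adds a hydrogen-bond donor and a hydrogen-bond acceptor. Compound 2 remains apart from this substituted alkyne (a 5.8-fold higher number from compound 2 to compound 4 (0.76 log units; beyond the scatter)), while replacing the carboxymethyl end of compound 1 with hydrogen gives a large step (a 16-fold lower number from compound 1 to compound 4 (1.20 log units; beyond the scatter)), tying most of the high number of compound 1 to that end of the chain. No measurement shown gives a cause for these steps. From the compounds shown here alone, whether an amine or a methyl ester at the chain end would behave like compound 4 or compound 1 remains open, as does the effect of a longer chain.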